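Fluorine on the benzyl ring of a hydrazone series

A few compounds are considered here, and "the series" means these few. Any claim that something is new, unique, unknown or untested is made for them only; others in the source may bear on it.

Compound 2 `CCCSc1nc(N/N=C(\C)c2ccccc2O)c2nnn(Cc3ccccc3)c2n1` serves as the reference point. In a functional assay on ECa-109 cells (Homo sapiens) for antiproliferative activity, read by MTT assay, with a stated time of 72 h (on this read-out lower numbers stand for stronger inhibition and higher numbers for weaker inhibition), compound 2 gives 11100 nM. Compound 1 `CCCSc1nc(N/N=C(\C)c2ccccc2O)c2nnn(Cc3ccc(F)cc3)c2n1` carries the change (fluoro in place of hydrogen on an aromatic carbon), and in this assay compound 1 gives 21900 nM; the step is a 2.0-fold higher number from compound 2 to compound 1 (0.30 log units; within the scatter). Compound 3 `CCCSc1nc(N/N=C/c2ccccc2)c2nnn(Cc3ccccc3)c2n1` differs from compound 2 by a group of 8 heavy atoms (7 carbon, 1 nitrogen; one six-membered aromatic ring of carbon only) in place of a group of 10 heavy atoms (8 carbon, 1 nitrogen, 1 oxygen; one six-membered aromatic ring of carbon only), on a nitrogen on an aromatic ring. For compound 3 the result in this assay is only a limit, > 64000 nM. The step of an at least 5.7-fold higher number from compound 2 to compound 3 (0.76 log units; beyond the scatter) is accordingly bounded on one side only, and compound 3 is the one entry sitting at the limit of > 64000 nM in this assay, at which 1 of the 3 values shown sits. Compound 4 `CCCSc1nc(N/N=C/c2ccccc2F)c2nnn(Cc3ccccc3)c2n1` has not yet been measured. It differs from compound 3 by fluoro in place of hydrogen on an aromatic carbon. This is the same kind of change as that from compound 2 to compound 1, though the place differs: in compound 1 the fluoro sits para to a large group, whereas in compound 4 it sits ortho to a large group. Because the measured step of a 2.0-fold higher number from compound 2 to compound 1 (0.30 log units; within the scatter) was small, and because compound 3 already sits at the limit of > 64000 nM in this assay, at which 1 of the 3 values shown sits, the step from compound 3 to compound 4 is estimated as a step that the limit leaves unreadable from compound 3 to compound 4, with a further limit the most likely outcome. Compound 4 is expected to give about 100000 nM, within 45000 nM to 250000 nM.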

Compound 4, half-maximal inhibitory concentration: > 64000 nM
Compound 4 gave a limit, no number; the forecaster's own chance of this, stated with the estimate: 80%; the middle value does not contradict the limit.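

In this assay compound 4 gives > 64000 nM, which is a limit of the assay and not a number. Fluoro in place of hydrogen on an aromatic carbon gave a 2.0-fold higher number from compound 2 to compound 1 (0.30 log units; within the scatter), but the size of the same change on the second core, where it sits ortho to a large group, cannot be read, because both compounds on that core stand at one limit: the limit of > 64000 nM in this assay, at which 2 of the 4 values shown sit. The one readable new step, an at least 5.7-fold higher number from compound 2 to compound 4 (0.76 log units; beyond the scatter), spans the whole group on the nitrogen and does not isolate the fluoro, so the data neither show that the change carries over from one core to the other nor show that it does not.

Going by these compounds, it remains open whether a chloro, a methoxy or an amine in place of that fluoro would give a value inside the range of the assay. Also open, on these data alone, is whether the hydroxyl or the methyl of compound 2 accounts for its readable value.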